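A few compounds are considered here, and "the series" means these few. Any claim that something is new, unique, unknown or untested is made for them only; others in the source may bear on it.

Measured so far:
compound 1, `Cc1ccc(-c2ccccc2OC(C)C2=NCCN2)cc1`: 0.46
compound 2, `CC(Oc1ccccc1-c1ccccc1[N+](=O)[O-])C1=NCCN1`: < 0.3

Two compounds of the series have been run in a functional assay on CHO cells for agonist activity at Alpha-2C adrenergic receptor (Homo sapiens); on this read-out higher numbers stand for larger maximal responses and lower numbers for smaller maximal responses. Compound 1 gives 0.46. For compound 2 the read-out is < 0.3, which is a limit of the assay and not a number. Compound 2 therefore stands at the limit of < 0.3 in this assay, at which 1 of the 2 values shown sits; it is the only one of the two to do so. For the measured compounds named here, no step between compound 1 and compound 2 has been computed, and nothing more can be said of the pair than what the two values show.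

Compound 3 `CC(Oc1ccccc1-c1ccccc1O)C1=NCCN1` has not yet been measured in this assay. It differs from compound 2 by hydroxy in place of nitro on an aromatic carbon. Because compound 2 sits at the limit of < 0.3 in this assay, at which 1 of the 2 values shown sits, the starting point of the step is itself uncertain, and any size for the step is a guess. The expected step a number at least 0.10 higher from compound 2 to compound 3 (that floor lies within the scatter) is upward, of modest size, taking the maximal response out of the limit region and towards that of compound 1. Compound 3 is estimated to give 0.4 in this assay, with a plausible range from 0.2 to 0.65.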

Compound 3, intrinsic activity: the largest response reached, as a fraction of the reference agonist's: < 0.3
Compound 3: a limit, no number (the forecaster's own chance of this, stated with the estimate: 25%); middle value at least 0.10 from the limit.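

In this assay compound 3 gives < 0.3, which is a limit of the assay and not a number. Hydroxy in place of nitro on an aromatic carbon leaves the read-out at that limit, and the step between these two compounds cannot be read, because neither end of it is a number: the limit of < 0.3 in this assay, at which 2 of the 3 values shown sit.

For the compounds shown here, the one readable step is a number at least 0.16 lower from compound 1 to compound 3 (beyond the scatter), with 2-hydroxyphenyl in place of 4-methylphenyl on an aromatic carbon, so this change to the aromatic group does not keep the maximal response seen with compound 1 in this assay.

That step changes both the position of the substituent on the aromatic ring and the substituent itself, so the compounds shown do not separate the contribution of each, and how far compound 2 and compound 3 differ from each other stays unknown. Open too, from the compounds shown here alone, is how an amine or a methoxy group on the same aromatic carbon would read, and how a methyl group there would compare with the 4-methylphenyl of compound 1.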